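The source may hold more compounds than are shown below. What is called first, only, known or untested is meant among the compounds shown, and "the series" means these compounds.

Measured in a functional assay on the whole organism (strain CF-1) with Mus musculus as the target, in the writhing test, with a stated time of 15 min; on this read-out higher numbers stand for an effect only at larger amounts of compound and lower numbers for an effect already at smaller amounts:
compound 1, `O=C(/N=C1\NC2(CCCCO2)CCS1)c1ccccc1`: 5 mg/kg
compound 2, `O=C(/N=C1\NC2(CCCCO2)CCS1)c1ccc(Br)cc1`: > 200 mg/kg, a limit of the assay rather than a number
compound 3, `O=C(/N=C1\NC2(CCCCO2)CCS1)c1ccc(Cl)cc1`: 1.1 mg/kg

Compound 3 holds the lowest of the two numbers; nearest is compound 1, a 4.5-fold lower number from compound 1 to compound 3 (0.66 log units; beyond the scatter). Compound 2 sits at the limit of > 200 mg/kg in this assay, at which 1 of the 3 values shown sits. Compound 4, `O=C(/N=C1\NC2(CCCCO2)CCS1)c1cccc(F)c1`, differs from compound 3 by 3-fluorophenyl in place of 4-chlorophenyl on a carbonyl carbon. On these data alone, the measured steps on the aromatic ring are a 4.5-fold lower number from compound 1 to compound 3 (0.66 log units; beyond the scatter), an at least 40-fold higher number from compound 1 to compound 2 (1.60 log units; beyond the scatter) and an at least 180-fold lower number from compound 2 to compound 3 (2.25 log units; beyond the scatter); none of them involves a 3-fluorophenyl, so the effect of the fluoro is untested here. Removal of the chloro reverses a 4.5-fold lower number from compound 1 to compound 3 (0.66 log units; beyond the scatter) and points back toward compound 1. Compound 4 is therefore expected to show a modest rise, a 4.5-fold higher number from compound 3 to compound 4 (0.66 log units; beyond the scatter). Compound 4 is estimated at 5 mg/kg, range 1.5 mg/kg to 25 mg/kg.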

Compound 4, dose for half-maximal effect: 9.2 mg/kg
Compound 4: middle estimate off by 1.8-fold (0.26 log units), on the low side; the measured number falls inside the stated range.
By their numbers in this assay, from the lowest: compound 3; then compounds 1 and 4 (each within the scatter of the next). At a limit, above all of these: compound 2.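

In this assay, the 3-fluorophenyl group on the carbonyl carbon cannot be told apart from the phenyl group of the parent, a 1.8-fold higher number from compound 1 to compound 4 (0.26 log units; within the scatter). Against 4-chlorophenyl it gives up ground, an 8.4-fold higher number from compound 3 to compound 4 (0.92 log units; beyond the scatter), yet it stays clear of 4-bromophenyl, an at least 21-fold lower number from compound 2 to compound 4 (1.33 log units; beyond the scatter). Compound 2 remains a limit rather than a number: the limit of > 200 mg/kg in this assay, at which 1 of the 4 values shown sits.

The step from 4-chlorophenyl to 3-fluorophenyl changes both the halogen and its place on the ring, and the share of each remains unresolved. On these data alone, how a methoxy or an amine on that ring would read also remains open.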